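Changing the Amide Aryl Group: Pyrrole to Methoxyphenyl

The compounds below may be only part of what the source reports. "The series", "measured", "known", "first", "only" and "open" are said of these compounds alone.

Three compounds built on one shared core were tested in a functional assay on MCF7 cells (Homo sapiens) for antiproliferative activity, read by MTT assay, with a stated time of 72 h; a higher number here means a weaker inhibitor, a lower number a stronger inhibitor. Compound 1 `CCN1CCN(c2cc(C)c3cc(NC(=O)c4ccc[nH]4)ccc3n2)CC1` gives 14700 nM. Compound 2 `Cc1cc(N2CCCC2)nc2ccc(NC(=O)c3ccc(Cl)c(Cl)c3)cc12` gives 26300 nM, and compound 3 `Cc1cc(N2CCN(C)CC2)nc2ccc(NC(=O)c3ccc(Cl)c(Cl)c3)cc12` gives 3000 nM. Among these three numbers compound 1 stands second highest: its value and that of compound 2 lie within the scatter of each other, while compound 3 sits beyond the scatter below it. Within the data shown here, the only step among measured compounds, an 8.8-fold lower number from compound 2 to compound 3 (0.94 log units; beyond the scatter), concerns the amine attached to the core and leaves the amide untouched. Compound 4 `CCN1CCN(c2cc(C)c3cc(NC(=O)c4ccccc4OC)ccc3n2)CC1` differs from compound 1 at the amide instead: 2-methoxyphenyl in place of 1H-pyrrol-2-yl on a carbonyl carbon. Among the measured compounds shown here, no measured pair shows this exchange, so the measured step gives no guide to its direction or size. The expected step of a 1.2-fold lower number from compound 1 to compound 4 (0.09 log units; within the scatter) is therefore one that may well fall within the scatter, in either direction. Compound 4 is estimated at 12000 nM, within a range from 3500 nM to 40000 nM.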

Compound 4, half-maximal inhibitory concentration: 13200 nM
The estimate for compound 4 lay 1.1-fold (0.04 log units) below the measured number, and the stated range covers the measured number.
By their numbers in this assay, from the lowest: compound 3; then compounds 4, 1 and 2 (each within the scatter of the next).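

In this assay, the group on the amide carbonyl can change considerably with no readable effect: 2-methoxyphenyl in place of 1H-pyrrol-2-yl gives a 1.1-fold lower number from compound 1 to compound 4 (0.05 log units; within the scatter), a difference within the scatter. The exchange replaces a five-membered aromatic ring holding a hydrogen-bond donor with a six-membered carbon ring holding a hydrogen-bond acceptor and no donor, so compound 4 shows that the donor of compound 1 is not required for activity at this level. No measurement here explains why the two groups read alike.

Still open, from the compounds shown here alone, is whether the methoxy group of compound 4 matters at all, which a plain phenyl group on the same carbonyl would test. A pyridine ring or a carboxylic acid at this place could also read differently.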